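Back from Ester to Anilide at the Chain End

The source may hold more compounds than are shown below. What is called first, only, known or untested is meant among the compounds shown, and "the series" means these compounds.

Of the compounds shown here, three sharing one core have been measured in an assay on isolated protein (Mus musculus) for inhibition of IL15-IL15 receptor (Homo sapiens), read by resazurin assay, with stated times of 30 min and 2.5 days; on this read-out higher numbers stand for weaker inhibition and lower numbers for stronger inhibition. Compound 1 `Cn1c(Cc2nn(C)c(=O)c3ccccc23)nnc1SCCCCCCCC(=O)Nc1ccc(F)cc1F` gives 2300 nM, compound 2 `Cn1c(Cc2nn(C)c(=O)c3ccccc23)nnc1SCCCCCCCC(=O)Nc1ccc(Cl)cc1Cl` gives 1900 nM, and compound 3 `Cn1c(Cc2nn(C)c(=O)c3ccccc23)nnc1SCCCCCCCC(=O)Oc1ccc(Cl)cc1Cl` gives 800 nM, the lowest of the three numbers. The step of a 1.2-fold lower number from compound 1 to compound 2 (0.08 log units; within the scatter) exchanged only halogens, whereas a 2.9-fold lower number from compound 1 to compound 3 (0.46 log units; beyond the scatter) and a 2.4-fold lower number from compound 2 to compound 3 (0.38 log units; beyond the scatter) each replaced an anilide by an aryl ester. Compound 4 `CC(C)COc1ccc(NC(=O)CCCCCCCSc2nnc(Cc3nn(C)c(=O)c4ccccc34)n2C)cc1` moves the other way: (4-(isobutoxy)phenyl)amino in place of 2,4-dichlorophenoxy on a carbonyl carbon. For the measured compounds named here, no measured pair covers the change of the aryl substituent itself. Because a 2.9-fold lower number from compound 1 to compound 3 (0.46 log units; beyond the scatter) and a 2.4-fold lower number from compound 2 to compound 3 (0.38 log units; beyond the scatter) both lowered the number modestly on forming the ester, the return to an amide-type nitrogen in compound 4 is expected to raise it by a similar amount, giving a 2.5-fold higher number from compound 3 to compound 4 (0.40 log units; beyond the scatter). Compound 4 is therefore estimated at 2000 nM, with a range from 800 nM to 5000 nM.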

Compound 4, half-maximal inhibitory concentration: 4800 nM
Compound 4: middle estimate off by 2.4-fold (0.38 log units), on the low side; the measured number falls inside the stated range.
By their numbers in this assay, from the lowest: compound 3; then compounds 2 and 1 (each within the scatter of the next); then compound 4.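

The aryl group on the amide-type nitrogen can move the number: both a 2.5-fold higher number from compound 2 to compound 4 (0.40 log units; beyond the scatter) and a 2.1-fold higher number from compound 1 to compound 4 (0.32 log units; beyond the scatter) lie beyond the scatter, which the exchange of one halogen for the other did not. For the compounds shown here, the larger 6.0-fold higher number from compound 3 to compound 4 (0.78 log units; beyond the scatter) changes the linking atom and the aryl group together, and these anilide steps show only that the aryl group matters on the amide side. Nothing available explains the effect of the 4-(isobutoxy)phenyl group.

Open, on these data alone, is how a 4-(isobutoxy)phenyl ester would read, which would separate the linking atom from the aryl group. Also open, as far as these compounds go, is how a carboxylic acid or an amine at the chain end, or a shorter chain, would read.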